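The source may report more compounds than this note shows. Statements on the series, on what has been measured and on what is new or still open speak of the compounds shown alone.

Compound 1 `COc1cc(/C(=N/OC(C)=O)c2ccc3c(ccn3C)c2)cc(OC)c1OC` was tested in a functional assay on HL-60 cells (Homo sapiens) for cytotoxicity, read by XTT assay, with a stated time of 72 h; a higher number here means a weaker inhibitor, a lower number a stronger inhibitor. In this assay compound 1 gives only a limit, > 10000 nM. Compound 2 `COc1cc(/C(=N\OC(C)=O)c2ccc3c(ccn3C)c2)cc(OC)c1OC` has the same atoms and bonds and differs from compound 1 only in the configuration as drawn. In this assay compound 2 likewise gives a limit, > 10000 nM. The step that the two limits leave unreadable from compound 1 to compound 2 therefore has no readable size; this rests on the limit of > 10000 nM in this assay, at which 2 of the 3 values shown sit, together with the fact that compounds 1 and 2 differ only in the configuration as drawn. Compound 3 `CCn1ccc2cc(/C(=N\OC(C)=O)c3cc(OC)c(OC)c(OC)c3)ccc21` differs from compound 1 by a methyl in place of hydrogen on a saturated chain carbon bound to an aromatic nitrogen. In this assay compound 3 gives a limit, > 1000 nM. The step that the two limits leave unreadable from compound 1 to compound 3 also cannot be sized, since the limit of > 1000 nM in this assay, at which 1 of the 3 values shown sits, and the limit of > 10000 nM in this assay, at which 2 of the 3 values shown sit, both stop short of a number. Compound 4 `COc1cc(/C(=N/N)c2ccc3c(ccn3C)c2)cc(OC)c1OC` is the next compound; it differs from compound 1 by amino in place of acetoxy on a double-bonded nitrogen. Neither measured step concerns this change, and neither has a readable size, so no direction can be drawn from them. The expectation for compound 4 is therefore that it remains near where compound 1 stands. Compound 4 is estimated at 10000 nM, within 2000 nM to 50000 nM. The step of a number no higher from compound 1 to compound 4 (the limit leaves the size open) implied by this estimate is expected to be no more than the scatter.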

Compound 4, half-maximal inhibitory concentration: > 10000 nM
Compound 4: no number, only a limit; the forecaster's own chance of this, stated with the estimate: 60%; the middle value sits exactly at the limit.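

In this assay compound 4 gives > 10000 nM, which is a limit and not a number. Compound 1 also gives only a limit, so no size can be read for the change between compound 1 and compound 4. The compounds shown leave open whether amino in place of acetoxy, the configuration or the added methyl shifts potency at all.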